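Fluoro for hydrogen across two related cores

The source may report more compounds than this note shows. Statements on the series, on what has been measured and on what is new or still open speak of the compounds shown alone.

Measured in a functional assay on A549 cells (Homo sapiens) for cytotoxicity, read by MTT assay, with a stated time of 72 h; a lower number here means a stronger inhibitor, a higher number a weaker inhibitor:
compound 1, `Cc1cc(=O)n(-c2ccc(F)c(F)c2)nc1C(=O)Nc1ccc(Oc2ncnc3ccsc23)cc1`: 8180 nM
compound 2, `Cc1cc(=O)n(-c2ccc(F)c(F)c2)nc1C(=O)Nc1ccc(Oc2ncnc3ccsc23)c(F)c1`: 4590 nM
compound 3, `Cc1cc(=O)n(-c2ccc(F)cc2)nc1C(=O)Nc1ccc(Oc2ncnc3sccc23)cc1`: 7050 nM

From compound 1 to compound 2 the change is fluoro in place of hydrogen on an aromatic carbon, and the step is a 1.8-fold lower number from compound 1 to compound 2 (0.25 log units; within the scatter). The difference between the core of compound 1 and the core of compound 3 is not broken down here; their values in this assay lie within the scatter of each other.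

Compound 4, `Cc1cc(=O)n(-c2ccc(F)c(F)c2)nc1C(=O)Nc1ccc(Oc2ncnc3sccc23)cc1`, is not yet measured. It differs from compound 3 by fluoro in place of hydrogen on an aromatic carbon, the same kind of change as from compound 1 to compound 2, but here the place is ortho to a fluoro group rather than ortho to a large group, while both sit meta to a large group.

Because the step of a 1.8-fold lower number from compound 1 to compound 2 (0.25 log units; within the scatter) stayed within the scatter, a step of similar size, a 1.6-fold lower number from compound 3 to compound 4 (0.19 log units; within the scatter), is expected. Compound 4 is estimated at 4500 nM, between 2000 nM and 10000 nM.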

Compound 4, half-maximal inhibitory concentration: 13500 nM
The estimate for compound 4 lay 3.0-fold (0.48 log units) below the measured number; the whole stated range lies below it.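

On the core of compound 3, fluoro in place of hydrogen gives in this assay a 1.9-fold higher number from compound 3 to compound 4 (0.28 log units; within the scatter), and with the 3,4-difluorophenyl group held constant, the change of core gives a 1.7-fold higher number from compound 1 to compound 4 (0.22 log units; within the scatter). Each step alone lies within the scatter, yet the fluoro change does not carry over unchanged between the two cores: the same change on two cores in this assay, a 1.8-fold lower number (0.25 log units; within the scatter) from compound 1 to compound 2 and a 1.9-fold higher number (0.28 log units; within the scatter) from compound 3 to compound 4, 3.4-fold (0.53 log units) apart, beyond the scatter of two such steps. This rests on one pair per core, with the fluoro entering at a different place in each pair, so it does not show that the core alone accounts for the gap, nor does it give a rule for other cores.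

Open, on these data alone, is whether fluoro at one and the same place would give matching steps on both cores. Also open, as far as these compounds go, is how chloro, methoxy or an amine at these places would behave on either core.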